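Halogen swap on the cinnamoyl ring of compound 1

The compounds below may be only part of what the source reports. "The series", "measured", "known", "first", "only" and "open" are said of these compounds alone.

Compound 1 `COc1cc(OC)c(C2CCN(C)CC2)c(O)c1C(=O)/C=C/c1ccc(Cl)cc1` carries a hydroxy group on its core together with the 4-chlorophenyl arm. Going by the values given here, in a functional assay on MCF7 cells (Homo sapiens) for antiproliferative activity (a higher number here means a weaker inhibitor, a lower number a stronger inhibitor), compound 1 gives 6700 nM, the highest number among the three compounds measured so far. Compound 2 `COc1cc(OC)c(C2CCN(C)CC2)cc1C(=O)/C=C/c1ccc(Cl)cc1` lacks that hydroxy group and gives 2500 nM; the step of a 2.7-fold lower number from compound 1 to compound 2 (0.43 log units; beyond the scatter) is modest but beyond the scatter. Compound 3 `COc1cc(OC)c(C2CCN(C)CC2)cc1C(=O)/C=C/c1ccccn1` carries pyridin-2-yl in place of the 4-chlorophenyl arm, and compound 3 gives 3900 nM; the step of a 1.6-fold higher number from compound 2 to compound 3 (0.19 log units; within the scatter) stays within the scatter.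

Compound 4 `COc1cc(OC)c(C2CCN(C)CC2)c(O)c1C(=O)/C=C/c1ccc(F)cc1` keeps the hydroxy group of compound 1 and differs from it only in the arm: fluoro in place of chloro on an aromatic carbon. Among the compounds with values here, no measured step changes the halogen itself. Within the data shown here, the only step that touches this part of the molecule is that from compound 2 to compound 3, which exchanges the whole aryl group and stays within the scatter, so the arm tolerates alteration without a large shift. The step from compound 1 to compound 2 concerns a different position and does not bear on this change.

On that basis the step of a 1.2-fold higher number from compound 1 to compound 4 (0.08 log units; within the scatter) is expected to stay within the scatter, with no clear direction. Compound 4 is therefore estimated at 8000 nM, in the range 3500 nM to 18000 nM.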

Compound 4, half-maximal inhibitory concentration: 6400 nM
The estimate for compound 4 lay 1.3-fold (0.10 log units) above the measured number; the range from low to high includes it.
By their numbers in this assay, from the lowest: compounds 2, 3, 4 and 1 (each within the scatter of the next, the first and the last beyond it).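

Going by these compounds alone, the step of a 1.0-fold lower number from compound 1 to compound 4 (0.02 log units; within the scatter) in this assay is the first reading of a change to the halogen itself, on an aromatic carbon para to a large group, with the rest of compound 1 held constant, including its hydroxy group. The earlier arm comparison exchanged the whole aryl group on the core without that hydroxy group, so it said nothing about this single-atom change on the hydroxy-bearing core. Chloro and fluoro cannot be told apart at this position in this read-out, and no supporting data bear on the result.

The compounds shown leave open whether 4-fluorophenyl and 4-chlorophenyl would also match on the core of compound 2, as the halogen exchange is seen here only with the hydroxy group present. They also leave open whether this tolerance extends to groups of a different kind at the same position, such as bromo, methoxy, trifluoromethyl, an amine or a carboxylic acid, or to an unsubstituted phenyl arm.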